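The source may report more compounds than this note shows. Statements on the series, on what has been measured and on what is new or still open speak of the compounds shown alone.

Compound 1 `CC(C)c1n[nH]c2c(NCc3ccc(-c4ccccn4)cc3)nc(SCCN)nc12`, compound 2 `CC(C)c1n[nH]c2c(NCc3ccc(-c4ccccn4)cc3)nc(SCCCN(C)C)nc12` and compound 3 `CC(C)c1n[nH]c2c(NCc3ccc(-c4ccccn4)cc3)nc(SCCNC(=N)N)nc12` share one core and differ only in the group on the sulfur. In a functional assay on HT cells (Homo sapiens) for antiproliferative activity, read by fluorescence, with a stated time of 72 h (a lower number here means a stronger inhibitor of growth, a higher number a weaker inhibitor of growth), compound 1 gives 22 nM, compound 2 gives 105 nM and compound 3 gives 390 nM, so compound 2 stands second highest of the three. Compound 4 `CCC(CO)Sc1nc(NCc2ccc(-c3ccccn3)cc2)c2[nH]nc(C(C)C)c2n1` changes that same chain: 1-(hydroxymethyl)propyl in place of 3-(dimethylamino)propyl on a sulfur. Among the compounds with values here, the steps that bear on it, a 4.8-fold higher number from compound 1 to compound 2 (0.68 log units; beyond the scatter) and a 3.7-fold higher number from compound 2 to compound 3 (0.57 log units; beyond the scatter), were both modest, and both kept a nitrogen in the chain, which compound 4 does not. A modest step upward is therefore expected, a 1.9-fold higher number from compound 2 to compound 4 (0.28 log units; within the scatter). Compound 4 is estimated at 200 nM, within 60 nM to 700 nM.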

Compound 4, concentration for 50% growth inhibition: 255 nM
Beside the measured number, compound 4's estimate is 1.3-fold (0.11 log units) below it; measured number inside the range.
By their numbers in this assay, from the lowest: compound 1; then compound 2; then compounds 4 and 3 (each within the scatter of the next).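

A nitrogen in the chain on the sulfur is not needed for activity in this assay: the nitrogen-free 1-(hydroxymethyl)propyl chain gives a 2.4-fold higher number from compound 2 to compound 4 (0.39 log units; beyond the scatter) and a 1.5-fold lower number from compound 3 to compound 4 (0.18 log units; within the scatter). Only the 2-aminoethyl chain stands well apart, with a 12-fold higher number from compound 1 to compound 4 (1.06 log units; beyond the scatter), although that change also alters the chain's shape, so the nitrogen's share cannot be separated out. Nothing available here explains these differences. Open, as far as these compounds go, is whether an unbranched 2-hydroxyethyl chain would fall nearer compound 1 or compound 4, and whether a branched chain carrying a primary amine would restore the activity of compound 1.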